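The compounds below may be only part of what the source reports. "The series", "measured", "known", "first", "only" and "open" are said of these compounds alone.

- Compound 1 `CC(C)Nc1nc(NCc2ccco2)c2ccccc2n1` gives 17000 nM here
- Compound 2 `Cc1ccccc1-c1nc(NCc2ccccc2)nc2ccccc12` gives "not determined" (no result reported) here
- Compound 3 `CNc1nc(NC(C)C)nc2ccccc12` gives "not determined" (no result reported) here

Going by the values given here, in an ADME assay on J774.A1 cells (Mus musculus) for inhibition, read by MTT assay, with a stated time of 72 h (a higher number here means that more compound is needed for the effect, a lower number that less compound is needed), compound 1 gives 17000 nM as the only number so far. Compound 2 and compound 3 have no result, so compound 1 cannot yet be ranked against another compound.

The next compound is compound 4 `c1coc(CNc2nc(NC3CCCCC3)nc3ccccc23)c1`, which keeps the shared core of compound 1 and differs in one group: cyclohexyl in place of isopropyl on a nitrogen on an aromatic ring. This places cyclohexyl in place of isopropyl on a nitrogen on an aromatic ring.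

Among the compounds with values here, no measured pair shows what this or any other single change does. The expectation therefore starts from compound 1 at 17000 nM and rests on the structural change alone. In this assay a small shift towards less compound needed is expected, possibly no larger than the usual scatter. The estimated change is a 1.7-fold lower number from compound 1 to compound 4 (0.23 log units; within the scatter) overall. For compound 4 the estimate is 10000 nM with an expected range from 3500 nM to 28000 nM in this assay.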

Compound 4, half-maximal effective concentration: 5300 nM
Estimate against measurement, compound 4: 1.9-fold (0.28 log units) above; low and high end bracket the measured number.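

In this assay the series now has one readable step, a 3.2-fold lower number from compound 1 to compound 4 (0.51 log units; beyond the scatter) with cyclohexyl in place of isopropyl on a nitrogen on an aromatic ring. Going by these compounds alone, this shows that the number responds to the group at this position, which the earlier compounds could not show. The change goes from 3 heavy atoms and no ring to 6 heavy atoms and one six-membered non-aromatic ring of carbon only, with the hydrogen-bond donor and acceptor counts of the group unchanged and no evidence on why the number moves.

Going by these compounds, it remains open whether the shift follows the ring itself or only the added carbon atoms, a question that a longer open chain at this nitrogen would address. On these data alone, how an amine or a carboxylic acid on the cyclohexyl ring would read also remains open.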